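Ortho substituent swap on the aminopyridine core: chloro to trifluoromethoxy

This account rests on a few compounds, and the source may have more. Where it says the series, first, only, none or still open, it means among the compounds named here.

Measured so far in an assay on HEK293 cells for inhibition of sodium channel protein type 10 subunit alpha (Homo sapiens), read by fluorescence; on this read-out higher numbers stand for weaker inhibition and lower numbers for stronger inhibition:
Compound 1, `CNC(=O)c1ccc(-c2cc(Cl)cc(Cl)c2)c(N)n1`, gives only a limit, > 32000 nM.
Compound 2, `Cn1nccc1C(=O)Nc1ccc(-c2cc(Cl)ccc2Cl)c(N)n1`, gives 920 nM.
Compound 3, `Cn1nccc1C(=O)Nc1ccc(-c2ccccc2Cl)c(N)n1`, gives 4900 nM.

Compound 3 thus gives the higher of the two numbers, with compound 2 the nearer one. Among the measured compounds shown here, the one measured step, a 5.3-fold higher number from compound 2 to compound 3 (0.73 log units; beyond the scatter), shows that losing a chloro costs potency. Compound 4, `Cn1nccc1C(=O)Nc1ccc(-c2ccccc2OC(F)(F)F)c(N)n1`, differs from compound 3 by trifluoromethoxy in place of chloro on an aromatic carbon. For the measured compounds named here, no measured step covers this exchange, so no direction beyond the scatter is expected in this assay. Compound 4 is estimated at 4000 nM, within 1200 nM to 14000 nM, which means an expected step of a 1.2-fold lower number from compound 3 to compound 4 (0.09 log units; within the scatter).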

Compound 4, half-maximal inhibitory concentration: 2400 nM
Compound 4: middle estimate off by 1.7-fold (0.22 log units), on the high side; the range from low to high includes it.
By their numbers in this assay, from the lowest: compound 2; then compound 4; then compound 3. At a limit, above all of these: compound 1.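

In this assay, trifluoromethoxy in place of chloro on an aromatic carbon, ortho to a large group, gives a 2.0-fold lower number from compound 3 to compound 4 (0.31 log units; beyond the scatter). This position therefore accepts a group of 5 heavy atoms in place of 1 with no loss, whereas the earlier step showed only the cost of removing a chloro. Nothing measured here accounts for this gain.

From the compounds shown here alone, whether methoxy or an amine would do as well at this position stays open. So does whether trifluoromethoxy would combine with the further chloro of compound 2.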